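A few compounds are considered here, and "the series" means these few. Any claim that something is new, unique, unknown or untested is made for them only; others in the source may bear on it.

Compound 1 `O=S(=O)(NCCCNc1nccc(-c2c(-c3cccc(F)c3)nc3sccn23)n1)c1cccc(F)c1` and compound 2 `O=S(=O)(NCCCNc1nccc(-c2c(-c3cccc(F)c3)nc3sccn23)n1)c1ccc(Br)cc1` share one core and differ only at the arylsulfonyl end. In a functional assay on SK-MEL-28 cells (Homo sapiens) for cytotoxicity, read by MTT assay (on this read-out higher numbers stand for weaker inhibition and lower numbers for stronger inhibition), compound 1 gives 8550 nM and compound 2 gives 9400 nM; the step of a 1.1-fold higher number from compound 1 to compound 2 (0.04 log units; within the scatter) stays within the scatter, so compound 2 stands as the higher of two numbers that are not separable. Compound 3 `O=S(=O)(NCCCNc1nccc(-c2c(-c3cccc(F)c3)nc3sccn23)n1)c1ccc(F)cc1` carries the change (fluoro in place of bromo on an aromatic carbon). For the measured compounds named here, only the step from compound 1 to compound 2 bears on this, and it showed nothing beyond the scatter; therefore no step beyond the scatter is expected in this assay, a 1.0-fold lower number from compound 2 to compound 3 (0.02 log units; within the scatter). Compound 3 is estimated at 9000 nM, range 4500 nM to 18000 nM.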

Compound 3, half-maximal inhibitory concentration: > 20000 nM
Compound 3: only a limit was reported; the forecaster's own chance of this, stated with the estimate: 5%; middle value at least 2.2-fold (0.34 log units) from the limit.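

In this assay the arylsulfonyl end proves sensitive after all: fluoro in place of bromo on the 4-substituted ring gives an at least 2.1-fold higher number from compound 2 to compound 3 (0.32 log units; beyond the scatter), unlike the earlier step within the scatter. Placement of the fluoro also counts, since 4-fluorophenyl in place of 3-fluorophenyl gives an at least 2.3-fold higher number from compound 1 to compound 3 (0.36 log units; beyond the scatter). Compound 3 carries only a limit of the assay: the limit of > 20000 nM in this assay, at which 1 of the 3 values shown sits.

Open, on these data alone, is how far compound 3 lies from compound 2 and compound 1. Also open, as far as these compounds go, is where a 4-chlorophenyl, a 4-methoxyphenyl or an amine on this ring would fall.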